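The compounds below may be only part of what the source reports. "The series", "measured", "known", "first", "only" and "open" are said of these compounds alone.

Working notes on the series in an assay on nucleic acid for binding affinity to Salmon testes DNA (Salmonidae), tested at 10 uM; on this read-out higher numbers stand for stronger stabilisation of the target against heat and lower numbers for weaker stabilisation of the target.

Three compounds have been run so far. Compound 1 `CN(C)CCCNC(=O)c1cc(NC(=O)c2cc(NC(=O)c3cc(NC(=N)N)cn3C)cn2C)cn1C` gives 5 degrees C. Compound 2 `CC(C)CCc1sc(NC(=O)c2cc(NC(=O)c3cc(NC(=N)c4cnc5ccccc5c4)cn3C)cn2C)nc1C(=O)NCCCN(C)C` gives 2 degrees C, and compound 3 `CC(C)CCc1sc(NC(=O)c2cc(NC(=O)c3cc(NC(=N)c4ccc(F)cc4)cn3C)cn2C)nc1C(=O)NCCCN(C)C` gives 9 degrees C. Among these, compound 1 stands second highest: compound 2 sits closest to it, a number below it beyond the scatter, and compound 3 sits furthest, a number above it beyond the scatter.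

Within the data shown here, the only single-point step measured so far is a number 7.0 degrees C higher from compound 2 to compound 3 (beyond the scatter), a large move that replaces quinolin-3-yl with 4-fluorophenyl on the carbon with a double bond to nitrogen, while the shared core of compound 2 and compound 3 stays the same.

Compound 4 `CN(C)CCCNC(=O)c1cc(NC(=O)c2cc(NC(=O)c3cc(NC(=N)c4ccccc4)cn3C)cn2C)cn1C` is not yet measured. It differs from compound 1 by phenyl in place of amino on a carbon with a double bond to nitrogen. Among the measured compounds shown here, no measured step swaps amino for an aromatic ring at this position, so the step from compound 2 to compound 3 bears only loosely on it: it shows that the group on this carbon can shift the read-out by a large amount, and that a six-membered aromatic ring of carbon only sits at the high end of what has been seen. On that basis a modest rise is expected, a number 1.5 degrees C higher from compound 1 to compound 4 (beyond the scatter), with wide uncertainty.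

Compound 4 is estimated at 6.5 degrees C, in a range from 2 degrees C to 11 degrees C.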

Compound 4, shift of the target's melting temperature: 11 degrees C
For compound 4 the middle estimate is 4.5 degrees C below the measured one; low and high end bracket the measured number.
By their numbers in this assay, from the lowest: compound 2; then compound 1; then compound 3; then compound 4.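

Among these compounds, this is the first measured exchange of amino for an aromatic ring at this position: in this assay, the change on the carbon with a double bond to nitrogen gives a number 6.0 degrees C higher from compound 1 to compound 4 (beyond the scatter) on the core of compound 1, even though a hydrogen-bond donor leaves and the entering phenyl brings none. The earlier step, a number 7.0 degrees C higher from compound 2 to compound 3 (beyond the scatter), exchanged one aromatic group for another on a different core, so a large move from the group on this carbon is now seen on two cores, and in both the higher number comes with a six-membered aromatic ring of carbon only. No measurement of any other kind bears on why the number rises here.

Going by these compounds, it remains open whether the rise requires an aromatic ring at all, which a cyclohexyl group on this carbon would test, and whether a pyridyl ring behaves like phenyl or falls towards quinolin-3-yl. Phenyl and 4-fluorophenyl stand on different cores, so the effect of the fluorine also remains open, as does whether 4-fluorophenyl would give a similar rise on the core of compound 1.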